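Methoxy on the benzoyl of a meta-linked amide

The source may report more compounds than this note shows. Statements on the series, on what has been measured and on what is new or still open speak of the compounds shown alone.

Among three compounds measured in an assay for inhibition of Amine oxidase [flavin-containing] B (Mus musculus), read by fluorescence, with a stated time of 30 min, in the presence of a further agent that is not named here (on this read-out higher numbers stand for weaker inhibition and lower numbers for stronger inhibition), compound 3 `Cn1c(=O)c2[nH]c(-c3cccc(NC(=O)c4ccccc4)c3)nc2n(C)c1=O` stands at the highest number, giving 4210 nM. Compound 1 `Cc1ccc(C(=O)Nc2ccc(-c3nc4c([nH]3)c(=O)n(C)c(=O)n4C)cc2)cc1` gives 2770 nM, a number within the scatter of compound 3. Compound 2 `Cn1c(=O)c2c(nc(-c3ccc(NC(=O)c4ccccc4)cc3)n2C)n(C)c1=O` gives 260 nM, a number well beyond the scatter below compound 3. Compound 4 `COc1ccc(C(=O)Nc2cccc(-c3nc4c([nH]3)c(=O)n(C)c(=O)n4C)c2)cc1` is not yet measured. It differs from compound 3 in one place: methoxy in place of hydrogen on an aromatic carbon. Going by the values given here, no measured pair here shows this same change, so its effect in this assay cannot be read from the data. He expects no step beyond the scatter from a 1.2-fold lower number from compound 3 to compound 4 (0.08 log units; within the scatter). For compound 4 he estimates 3500 nM, with a range from 1200 nM to 10000 nM.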

Compound 4, inhibition constant: 3490 nM
Compound 4: the middle estimate sits 1.0-fold (0.00 log units) above what was measured, and the stated range covers the measured number.
By their numbers in this assay, from the lowest: compound 2; then compounds 1, 4 and 3 (each within the scatter of the next).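

In this assay this change now has its first measured case, a 1.2-fold lower number from compound 3 to compound 4 (0.08 log units; within the scatter) and so no step beyond the scatter. On this compound, then, going from phenyl to 4-methoxyphenyl, with the methoxy para to a large group, leaves the number in place. Nothing at hand offers a reason for this result.

The compounds shown leave open what an amine or a longer chain such as ethoxy would do at this place. They also leave open whether the same change would give a like step on compound 2.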